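A few compounds are considered here, and "the series" means these few. Any claim that something is new, unique, unknown or untested is made for them only; others in the source may bear on it.

Growth-inhibition values in a functional assay on OVCAR-3 cells (Homo sapiens) for inhibition, read by sulforhodamine B assay, with a stated time of 48 h (a lower number here means a stronger inhibitor of growth, a higher number a weaker inhibitor of growth), for the three measured compounds:

compound 1 `COc1cc(-c2cc(/C=C/C(=O)c3ccc(N)cc3)[nH]n2)cc(OC)c1OC` gives 3370 nM
compound 2 `COc1ccc(C(=O)/C=C/c2cc(-c3cc(OC)c(OC)c(OC)c3)n[nH]2)cc1OC` gives 3170 nM
compound 3 `COc1ccc(C(=O)/C=C/c2cc(-c3cc(OC)c(OC)c(OC)c3)n[nH]2)cc1` gives 3560 nM

Compound 3 carries the highest of the three numbers, but its neighbours sit within the scatter: a 1.1-fold higher number from compound 1 to compound 3 (0.02 log units; within the scatter) and a 1.1-fold higher number from compound 2 to compound 3 (0.05 log units; within the scatter). The remaining pair, a 1.1-fold lower number from compound 1 to compound 2 (0.03 log units; within the scatter), is likewise within the scatter. All three steps concern the aryl group on the carbonyl carbon, and none of them moves the number beyond the scatter.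

Compound 4 `COc1cc(-c2cc(/C=C/C(=O)c3ccc(F)c(F)c3)[nH]n2)cc(OC)c1OC` is not yet measured. It differs from compound 3 in one place: 3,4-difluorophenyl in place of 4-methoxyphenyl on a carbonyl carbon. The three measured steps bear directly on this, since each swaps substituents on that same ring, and each was within the scatter. The expectation for this assay is therefore a step of no more than the scatter in either direction.

Compound 4 is estimated at 3500 nM, with a range of 1500 nM to 8000 nM. The expected step is a 1.0-fold lower number from compound 3 to compound 4 (0.01 log units; within the scatter), within the scatter.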

Compound 4, concentration for total growth inhibition: 6250 nM
The estimate for compound 4 lay 1.8-fold (0.25 log units) below the measured number; the range from low to high includes it.
By their numbers in this assay, from the lowest: compounds 2, 1, 3 and 4 (each within the scatter of the next).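

In this assay, 3,4-difluorophenyl on the carbonyl carbon takes the place of three other aryl groups (a 1.8-fold higher number from compound 3 to compound 4 (0.24 log units; within the scatter); a 2.0-fold higher number from compound 2 to compound 4 (0.29 log units; within the scatter); a 1.9-fold higher number from compound 1 to compound 4 (0.27 log units; within the scatter)), and each step stays within the scatter. Where the earlier compounds varied only methoxy and amino substituents on this ring, compound 4 shows that fluorine in place of those groups also leaves the number within the scatter of all three, so among these four compounds no aryl group at this position stands apart. Nothing here bears on why the value of compound 4 falls where it does.

Still open, as far as these compounds go, is whether this position stays as flat with a group other than a substituted phenyl, such as a pyridine ring, a cyclohexyl ring or a short alkyl chain on the carbonyl carbon. A carboxylic acid on the ring is equally untested in the compounds shown, as is any change to the 3,4,5-trimethoxyphenyl group held constant across the series.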